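Swapping the thiophene ring on a dihydropyridine scaffold

The compounds below may be only part of what the source reports. "The series", "measured", "known", "first", "only" and "open" are said of these compounds alone.

Measured so far:
compound 1 `COC(=O)C1=C(C)NC(C)=C(C(=O)OC)C1c1c(-c2c(Cl)csc2Cl)nc2sc(C)cn12` gives 3230 nM
compound 2 `COC(=O)C1=C(C)NC(C)=C(C(=O)OC)C1c1c(-c2ccsc2)nc2sc(C)cn12` gives 3520 nM
compound 3 `COC(=O)C1=C(C)NC(C)=C(C(=O)OC)C1c1c(-c2ccsc2)nc2sccn12` gives 2.3 nM

The read-out in each case is a functional assay on ileum (Cavia porcellus) for inhibition; a higher number here means a weaker inhibitor, a lower number a stronger inhibitor. Compound 2 and compound 1 differ by a group of 7 heavy atoms (4 carbon, 1 sulfur, 2 chlorine; one five-membered aromatic ring with 1 hetero atom) in place of a group of 5 heavy atoms (4 carbon, 1 sulfur; one five-membered aromatic ring with 1 hetero atom), on an aromatic carbon; the step of a 1.1-fold lower number from compound 2 to compound 1 (0.04 log units; within the scatter) is within the scatter, so those two values show no difference of note. Compound 2 and compound 3 differ by hydrogen in place of methyl on an aromatic carbon, and here the step of a 1500-fold lower number from compound 2 to compound 3 (3.18 log units; beyond the scatter) is large, leaving compound 3 with the lowest number of the three.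

Compound 4 `COC(=O)C1=C(C)NC(C)=C(C(=O)OC)C1c1c(-c2c(Cl)csc2Cl)nc2sccn12` has not been measured. It differs from compound 3 by a group of 7 heavy atoms (4 carbon, 1 sulfur, 2 chlorine; one five-membered aromatic ring with 1 hetero atom) in place of a group of 5 heavy atoms (4 carbon, 1 sulfur; one five-membered aromatic ring with 1 hetero atom), on an aromatic carbon. This is the same change as from compound 2 to compound 1, and the place lines match word for word, so the two changes are alike in every counted respect. Among the compounds with values here, the only guide to its size is a 1.1-fold lower number from compound 2 to compound 1 (0.04 log units; within the scatter), which is within the scatter, so the step from compound 3 to compound 4 is expected to be small: a 1.1-fold higher number from compound 3 to compound 4 (0.04 log units; within the scatter). Compound 4 is therefore estimated at 2.5 nM, with a likely range from 0.8 nM to 8 nM.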

Compound 4, half-maximal inhibitory concentration: 180 nM
For compound 4 the middle estimate is 72-fold (1.86 log units) below the measured one; measured number outside the range, above it.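

In this assay, putting the chlorine-bearing ring in place of thiophen-3-yl made no clear difference on the methyl-bearing core, but on the core without that methyl it gave a 78-fold higher number from compound 3 to compound 4 (1.89 log units; beyond the scatter), so the size of this change did not carry from one core to the other: the same change on two cores in this assay, a 1.1-fold lower number (0.04 log units; within the scatter) from compound 2 to compound 1 and a 78-fold higher number (1.89 log units; beyond the scatter) from compound 3 to compound 4, 85-fold (1.93 log units) apart, beyond the scatter of two such steps. Read the other way, hydrogen in place of methyl gave a lower number with either ring, but the size of that step also depended on the partner, with an 18-fold lower number from compound 1 to compound 4 (1.25 log units; beyond the scatter) here and a much larger step for the thiophen-3-yl pair: the same change on two cores in this assay, a 1500-fold lower number (3.18 log units; beyond the scatter) from compound 2 to compound 3 and an 18-fold lower number (1.25 log units; beyond the scatter) from compound 1 to compound 4, 85-fold (1.93 log units) apart, beyond the scatter of two such steps. The two changes therefore do not act independently in these four compounds, but this single set of pairs does not show why, nor whether the same holds for other groups in the series.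

The compounds shown leave open how an ethyl group or a chlorine atom would behave in place of that methyl. On these data alone, it also remains open whether a phenyl ring in place of the thiophene would show the same dependence on the core.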